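This account rests on a few compounds, and the source may have more. Where it says the series, first, only, none or still open, it means among the compounds named here.

In a physicochemical assay for solubility, in simulated intestinal fluid, measured as thermodynamic solubility, at pH 6.8 (a higher number here means a more soluble compound, a lower number a less soluble compound), three compounds with a shared core have been measured. Compound 1 `CCC(CC)N1CCN(c2nc3c(c(Nc4ccc(C(F)(F)F)cc4)n2)CCN(c2ncccc2C(F)(F)F)CC3)CC1` reaches 109 ug/mL and compound 2 `CN1CCCCC1CNc1nc2c(c(Nc3ccc(C(F)(F)F)cc3)n1)CCN(c1ncccc1C(F)(F)F)CC2` reaches 254 ug/mL while compound 3 `CNC1CCN(c2nc3c(c(Nc4ccc(C(F)(F)F)cc4)n2)CCN(c2ncccc2C(F)(F)F)CC3)C1` reaches 233 ug/mL on the same scale. Compound 3 thus stands with compound 2 at the upper end of the three (the step of a 1.1-fold lower number from compound 2 to compound 3 (0.04 log units; within the scatter) stays within the scatter), and both lie beyond the scatter from compound 1 (steps of a 2.3-fold higher number from compound 1 to compound 2 (0.37 log units; beyond the scatter) and a 2.1-fold higher number from compound 1 to compound 3 (0.33 log units; beyond the scatter) which are modest). Compound 4 `FC(F)(F)c1ccc(Nc2nc(NC3CCCNC3)nc3c2CCN(c2ncccc2C(F)(F)F)CC3)cc1` carries (piperidin-3-yl)amino in place of 3-(methylamino)pyrrolidin-1-yl on an aromatic carbon. Among the compounds with values here, no measured step makes this exact exchange. Within the data shown here, the closest precedent is the swap at the same carbon between the groups of compound 2 and compound 3 (a 1.1-fold lower number from compound 2 to compound 3 (0.04 log units; within the scatter)), so no change beyond the scatter is expected in this assay. The expected move is a 1.0-fold lower number from compound 3 to compound 4 (0.02 log units; within the scatter) and so remains within the scatter. Compound 4 is estimated at 225 ug/mL (expected range 115 ug/mL to 440 ug/mL).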

Compound 4, solubility: 203 ug/mL
Estimate against measurement, compound 4: 1.1-fold (0.04 log units) above; the range from low to high includes it.
By their numbers in this assay, from the lowest: compounds 1, 4, 3 and 2 (each within the scatter of the next, the first and the last beyond it).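

In this assay, rearranging the same atoms from 3-(methylamino)pyrrolidin-1-yl into (piperidin-3-yl)amino gives a 1.1-fold lower number from compound 3 to compound 4 (0.06 log units; within the scatter), so this exchange on the carbon between two ring nitrogen atoms leaves the reading unresolved from that of compound 3. The step of a 1.3-fold lower number from compound 2 to compound 4 (0.10 log units; within the scatter) likewise stays within the scatter, which places compound 4 with compound 2 as well. Yet a 1.9-fold higher number from compound 1 to compound 4 (0.27 log units; within the scatter) also stays within the scatter, unlike the steps from compound 1 to compound 2 and compound 3, so compound 4 cannot be separated from any of the other three, and nothing shown bears on a cause for these numbers.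

The compounds shown leave open whether a morpholin-4-yl group or a carboxylic acid at this carbon would move the number beyond the scatter. They also leave open how a methyl group on the piperidine nitrogen of compound 4 would read.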